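Aryl swaps on the piperazine nitrogen of the shared core

The source may hold more compounds than are shown below. What is called first, only, known or untested is meant among the compounds shown, and "the series" means these compounds.

Measured so far:
- compound 1, `Cc1ccc(N2CCN(Cn3nc(-c4ccc5c(c4)OCCO5)oc3=S)CC2)c(C)c1`: > 50000 nM
- compound 2, `COc1cccc(N2CCN(Cn3nc(-c4ccc5c(c4)OCCO5)oc3=S)CC2)c1`: 18000 nM
- compound 3, `O=[N+]([O-])c1ccc(N2CCN(Cn3nc(-c4ccc5c(c4)OCCO5)oc3=S)CC2)cc1`: 31700 nM

In a functional assay on HeLa cells (Homo sapiens) for antiproliferative activity, read by MTT assay, with a stated time of 48 h (on this read-out higher numbers stand for weaker inhibition and lower numbers for stronger inhibition), compound 1 gives only a limit, > 50000 nM; this is an assay floor and not a number (the limit of > 50000 nM in this assay, at which 1 of the 3 values shown sits). Compound 3 carries the highest of the two real numbers in this assay; its nearest neighbour is compound 2, and the gap a 1.8-fold higher number from compound 2 to compound 3 (0.25 log units; within the scatter) is within the scatter. Against compound 1, the step of an at least 1.5-fold lower number from compound 1 to compound 3 (0.19 log units; that floor lies within the scatter) has a floor within the scatter, whereas an at least 2.7-fold lower number from compound 1 to compound 2 (0.44 log units; beyond the scatter) is at least modest.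

Compound 4, `S=c1oc(-c2ccc3c(c2)OCCO3)nn1CN1CCN(c2ccccn2)CC1`, is not yet measured. It differs from compound 3 by pyridin-2-yl in place of 4-nitrophenyl on an amine nitrogen in a ring. All three measured steps are aryl swaps on that same ring nitrogen, and none of them moves the number by more than a modest amount. Compound 4 is therefore expected to stay near compound 3, with the step of a 1.3-fold lower number from compound 3 to compound 4 (0.10 log units; within the scatter) not beyond the scatter. The estimate for compound 4 in this assay is 25000 nM, within 8000 nM to 80000 nM.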

Compound 4, half-maximal inhibitory concentration: 25100 nM
Compound 4: middle estimate off by 1.0-fold (0.00 log units), on the low side; low and high end bracket the measured number.
By their numbers in this assay, from the lowest: compounds 2, 4 and 3 (each within the scatter of the next). At a limit, above all of these: compound 1.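

In this assay, pyridin-2-yl brings the first aromatic ring with a hetero atom onto this ring nitrogen, and neither step to it leaves the scatter (a 1.3-fold lower number from compound 3 to compound 4 (0.10 log units; within the scatter); a 1.4-fold higher number from compound 2 to compound 4 (0.14 log units; within the scatter)). Compound 2, compound 3 and compound 4 therefore cannot be told apart here, so removing the 4-nitrophenyl ring's carbon-only character and its nitro group shows no readable effect at this position. The step from the limit does not separate compound 4 either (an at least 1.9-fold lower number from compound 1 to compound 4 (0.29 log units; that floor lies within the scatter)), and compound 1 remains a limit, not a number: the limit of > 50000 nM in this assay, at which 1 of the 4 values shown sits.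

The compounds shown leave open whether an aromatic ring carrying an amine or a carboxylic acid would move the number beyond the scatter. Also open, going by these compounds, is what a saturated ring or a longer alkyl chain on this nitrogen would do in place of an aromatic ring.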